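The compounds below may be only part of what the source reports. "The series", "measured", "known", "first", "only" and "open" are said of these compounds alone.

Compound 2, `Cc1cc(C)cc(-n2nncc2CN2C(=O)C3(C(C#N)=C(N)Oc4c(N)cc5nc6ccccc6nc5c43)c3ccccc32)c1`, is the point of departure. In an ADME assay on HUVEC cells (Homo sapiens) for antiproliferative activity, read by MTT assay, with a stated time of 48 h (a higher number here means a weaker inhibitor, a lower number a stronger inhibitor), compound 2 gives > 50000 nM, a value that is a limit of the assay rather than a number. Among the measured compounds shown here, its only measured neighbour is compound 1, `N#CC1=C(N)Oc2c(N)cc3nc4ccccc4nc3c2C12C(=O)N(Cc1cnnn1-c1ccc(F)cc1)c1ccccc12`, which carries 4-fluorophenyl where compound 2 carries 3,5-dimethylphenyl on an aromatic nitrogen. In this assay compound 1 gives > 50000 nM, again a limit. The step that the two limits leave unreadable from compound 1 to compound 2 is thus one that the two limits leave unreadable, and the limit of > 50000 nM in this assay, at which 2 of the 2 values shown sit, is all the evidence there is. Compound 3, `N#CC1=C(N)Oc2c(N)cc3nc4ccccc4nc3c2C12C(=O)N(Cc1cnnn1-c1ccc(Cl)cc1Cl)c1ccccc12`, is the compound still to be measured. The change is 2,4-dichlorophenyl in place of 3,5-dimethylphenyl on an aromatic nitrogen. For the measured compounds named here, only the step from compound 1 to compound 2 concerns the same position, and that step is not readable; no size or direction can be taken from it, and the two limits give no sign that the aryl group on the aromatic nitrogen moves the read-out into the measurable range. Compound 3 is therefore expected to stay at the limit, with the step that the limit leaves unreadable from compound 2 to compound 3 expected to be none beyond the scatter. For compound 3 the estimate in this assay is 80000 nM, within a range from 30000 nM to 300000 nM.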

Compound 3, half-maximal inhibitory concentration: > 50000 nM
Compound 3: a limit, no number; the forecaster's own chance of this, stated with the estimate: 85%; the middle value does not contradict the limit.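

In this assay compound 3 gives > 50000 nM, which is a limit and not a number. Among the compounds shown here, no step among compound 1, compound 2 and compound 3 can be read, and what remains is this: the limit of > 50000 nM in this assay, at which 3 of the 3 values shown sit. The compounds shown leave open whether any aryl group on the aromatic nitrogen brings the read-out into the measurable range.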